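Ethyl for hydrogen on the amide chain in two cores

The source may report more compounds than this note shows. Statements on the series, on what has been measured and on what is new or still open speak of the compounds shown alone.

Compound 1 `COc1ccc2cccc(CONC(C)=O)c2c1` and compound 2 `CCCC(=O)NOCc1cccc2ccc(OC)cc12` share one core; compound 3 `COc1ccc2c(c1)C=C(CNC(C)=O)CO2` is built on a different core, and the difference between the two cores is not broken down here. In an assay (Ovis aries) for binding affinity to melatonin receptor type 1A (Homo sapiens) (on this read-out lower numbers stand for stronger inhibition and higher numbers for weaker inhibition), compound 1 gives 7.94 nM and compound 2 gives 3.98 nM. The change between them is ethyl in place of hydrogen on a saturated chain carbon bound to a carbonyl carbon and the step it made is a 2.0-fold lower number from compound 1 to compound 2 (0.30 log units; within the scatter). In this assay compound 3 gives 15800 nM, the highest of the three numbers, beyond the scatter from both compound 1 and compound 2.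

Compound 4 `CCCC(=O)NCC1=Cc2cc(OC)ccc2OC1`, not yet measured, carries the same change on the core of compound 3: ethyl in place of hydrogen on a saturated chain carbon bound to a carbonyl carbon. The place is the same word for word as in the first pair, so this is the same change, made twice among the compounds shown. Going by the values given here, only one measured instance exists, and that one lies within the scatter, so the expectation rests on the single step of a 2.0-fold lower number from compound 1 to compound 2 (0.30 log units; within the scatter) transferred to a core for which no such step has been measured. The expected step is a 2.0-fold lower number from compound 3 to compound 4 (0.30 log units; within the scatter), beside the earlier one. For compound 4 in this assay the estimate is 8000 nM, with a range from 2500 nM to 30000 nM. The range is kept wide since compound 3 sits far from the other two, as 15800 nM shows.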

Compound 4, half-maximal inhibitory concentration: 20 nM
Compound 4: the middle estimate sits 400-fold (2.60 log units) above what was measured, outside the stated range (below it).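

On the core of compound 3, ethyl in place of hydrogen on a saturated chain carbon bound to a carbonyl carbon gives a 790-fold lower number from compound 3 to compound 4 (2.90 log units; beyond the scatter) in this assay, so the large effect seen there was not foreshadowed by the step on the core of compound 1. The two cores do not respond to this change by the same amount, and its size cannot be carried from one core to the other in this series: the same change on two cores in this assay, a 2.0-fold lower number (0.30 log units; within the scatter) from compound 1 to compound 2 and a 790-fold lower number (2.90 log units; beyond the scatter) from compound 3 to compound 4, 400-fold (2.60 log units) apart, beyond the scatter of two such steps. This rests on one pair for each core, so it does not show why the steps part, how the change would behave on any further core, or whether the two steps share a direction, as the step on the core of compound 1 lies within the scatter.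

As far as these compounds go, it remains open whether the large step on the core of compound 3 is particular to ethyl or would also appear with methyl or a longer chain such as butyl in the same place. Also open, from the compounds shown here alone, is whether such a chain would produce a step beyond the scatter on the core of compound 1, or leave that core as little moved as ethyl did.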